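From morpholin-3-yl to 1-acetylazetidin-3-yl on the amide chain

This account rests on a few compounds, and the source may have more. Where it says the series, first, only, none or still open, it means among the compounds named here.

Compound 1 `CNC(=O)c1ccncc1Nc1cc(-c2ccc3ccn(C)c3c2)c2nccnc2c1` gives 83 nM in an assay for inhibition of 6-phosphofructo-2-kinase/fructose-2,6-bisphosphatase 3 (Homo sapiens), read by ADP-Glo, with a stated time of 2 h; on this read-out higher numbers stand for weaker inhibition and lower numbers for stronger inhibition.
Compound 2 `CN(C)C(=O)c1ccncc1Nc1cc(-c2ccc3ccn(C)c3c2)c2nccnc2c1` gives 499 nM in this assay.
Compound 3 `Cn1ccc2ccc(-c3cc(Nc4cnccc4C(=O)NCC4COCCN4)cc4nccnc34)cc21` gives 33 nM in this assay.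

Compound 3 stands lowest of the three numbers. Its nearest neighbour is compound 1, separated by a 2.5-fold lower number from compound 1 to compound 3 (0.40 log units; beyond the scatter), and compound 2 lies furthest away, a 15-fold lower number from compound 2 to compound 3 (1.18 log units; beyond the scatter). Compound 4 `CC(=O)N1CC(CNC(=O)c2ccncc2Nc2cc(-c3ccc4ccn(C)c4c3)c3nccnc3c2)C1` differs from compound 3 in one place: 1-acetylazetidin-3-yl in place of morpholin-3-yl on a saturated chain carbon bound to an amide-type nitrogen. Going by the values given here, only one measured step touches that chain carbon, namely a 2.5-fold lower number from compound 1 to compound 3 (0.40 log units; beyond the scatter), in which the ring replaced a hydrogen; that step was modest. The step of a 6.0-fold higher number from compound 1 to compound 2 (0.78 log units; beyond the scatter) concerns the amide nitrogen itself, which is left untouched here. No measured pair compares two different rings on that chain carbon, so the consequence of exchanging one ring for another is not shown by the data. For compound 4 a step of moderate size at most is expected, most likely toward a slightly higher number, a 1.8-fold higher number from compound 3 to compound 4 (0.26 log units; within the scatter). Compound 4 is accordingly estimated at 60 nM, within a range from 20 nM to 180 nM.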

Compound 4, half-maximal inhibitory concentration: 137 nM
Beside the measured number, compound 4's estimate is 2.3-fold (0.36 log units) below it; the measured number falls inside the stated range.
By their numbers in this assay, from the lowest: compound 3; then compounds 1 and 4 (each within the scatter of the next); then compound 2.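

Going by these compounds alone, this is the first comparison of two rings on the saturated chain carbon bound to an amide-type nitrogen, and in this assay the choice of ring shows up clearly, with 1-acetylazetidin-3-yl in place of morpholin-3-yl (a 4.2-fold higher number from compound 3 to compound 4 (0.62 log units; beyond the scatter)). The lower number that morpholin-3-yl brought over hydrogen does not carry over to 1-acetylazetidin-3-yl (a 1.7-fold higher number from compound 1 to compound 4 (0.22 log units; within the scatter)), though the ((1-acetylazetidin-3-yl)methyl)amino group still compares well with dimethylamino on the carbonyl carbon (a 3.6-fold lower number from compound 2 to compound 4 (0.56 log units; beyond the scatter)). Nothing available explains the difference between the two rings.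

The compounds shown leave open whether the step follows the ring size, the ring atoms or the acetyl group, since these all change together here. Azetidin-3-yl without the acetyl group, or 1-acetylpiperidin-4-yl, on the same chain carbon would begin to separate them.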